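Pyrrolidin-1-yl in place of butylamino on the amide

This account rests on a few compounds, and the source may have more. Where it says the series, first, only, none or still open, it means among the compounds named here.

In a functional assay on HL-60 cells (Homo sapiens) for antiproliferative activity, read by MTT assay, with a stated time of 24 h (a lower number here means a stronger inhibitor, a higher number a weaker inhibitor), compound 3 `CCCCNC(=O)COc1ccc(C(=O)c2c(CCCC)oc3ccccc23)cc1` gives > 50000 nM as a limit and not a number. Compound 1 `CCCCc1oc2ccccc2c1C(=O)c1ccc(OCC(N)=O)cc1` gives > 50000 nM as a limit too. Compound 2 `CCCCc1oc2ccccc2c1C(=O)c1ccc(OCC(=O)NC(C)C)cc1` alone gives a true number (360 nM). Two large steps show how much the group on the amide nitrogen can matter: with isopropyl in place of hydrogen there is an at least 130-fold lower number from compound 1 to compound 2 (2.14 log units; beyond the scatter) and with butyl in place of isopropyl there is an at least 130-fold higher number from compound 2 to compound 3 (2.14 log units; beyond the scatter) in the same test. Compound 4 `CCCCc1oc2ccccc2c1C(=O)c1ccc(OCC(=O)N2CCCC2)cc1` carries pyrrolidin-1-yl in place of butylamino on a carbonyl carbon. Within the data shown here, none of the measured compounds has this ring, so the expectation is loose: a sizeable move towards a lower number, with a real chance of staying at the limit. The expected step is an at least 8.3-fold lower number from compound 3 to compound 4 (0.92 log units; beyond the scatter) in this assay and remains uncertain. Compound 4 is estimated at 6000 nM with an expected range from 500 nM to 50000 nM in this test.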

Compound 4, half-maximal inhibitory concentration: > 50000 nM
Compound 4: no number, only a limit (the forecaster's own chance of this, stated with the estimate: 40%); at least 8.3-fold (0.92 log units) between middle value and limit.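

In this assay, pyrrolidin-1-yl does not keep the activity seen with isopropylamino: there is an at least 130-fold higher number from compound 2 to compound 4 (2.14 log units; beyond the scatter). Pyrrolidin-1-yl has no amide hydrogen, whereas butylamino and amino do, yet compound 1, compound 3 and compound 4 all end at a limit, so that hydrogen alone does not separate them here. The steps to compound 4 from compound 1 and compound 3 cannot be read because both ends of each are limits: the limit of > 50000 nM in this assay, at which 3 of the 4 values shown sit.

Going by these compounds, whether tert-butylamino or cyclopropylamino would give a true number remains open. So does whether a larger ring, such as piperidin-1-yl, would stay at the limit.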